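Chain lengthening on a hydrazone of a nitrophenyl thiazole

The source may report more compounds than this note shows. Statements on the series, on what has been measured and on what is new or still open speak of the compounds shown alone.

Among the measured compounds shown here, compound 1 `CCC(CC)=NNc1nc(-c2cccc([N+](=O)[O-])c2)cs1` stands highest of the two numbers so far in an assay on isolated protein for inhibition of Amine oxidase [flavin-containing] A (Homo sapiens), read by fluorescence, with a stated time of 20 min (a lower number here means a stronger inhibitor, a higher number a weaker inhibitor), where compound 1 gives 24300 nM. Its nearest neighbour is compound 2 `C=CCC/C(C)=N\Nc1nc(-c2cccc([N+](=O)[O-])c2)cs1`, which in this assay gives 3990 nM; the step of a 6.1-fold lower number from compound 1 to compound 2 (0.78 log units; beyond the scatter) came with a longer chain on the nitrogen of the shared core. Compound 3 `CCCCC/C(CC)=N\Nc1nc(-c2cccc([N+](=O)[O-])c2)cs1` differs from compound 1 by propyl in place of hydrogen on a saturated chain carbon, two bonds along the chain from a carbon with a double bond to nitrogen, again lengthening the chain on the same side of the hydrazone. For the measured compounds named here, only the step from compound 1 to compound 2 bears on this, and it favoured the longer chain by a modest margin beyond the scatter, so a lower number in this assay is expected for compound 3, though a saturated propyl need not repeat the full size of that step. Compound 3 is therefore estimated at 6500 nM in this assay, within 2000 nM to 22000 nM, an expected step of a 3.7-fold lower number from compound 1 to compound 3 (0.57 log units; beyond the scatter).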

Compound 3, half-maximal inhibitory concentration: 7150 nM
Compound 3: the middle estimate sits 1.1-fold (0.04 log units) below what was measured; measured number inside the range.
By their numbers in this assay, from the lowest: compounds 2 and 3 (each within the scatter of the next); then compound 1.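

The propyl on this saturated chain carbon gave a 3.4-fold lower number from compound 1 to compound 3 (0.53 log units; beyond the scatter) in this assay, so a lower number than that of compound 1 does not depend on a carbon-carbon double bond in the added chain, as compound 2 alone could not show. Compound 3 also keeps an ethyl on the other side of the hydrazone, so lengthening one side of compound 1 is enough for a step beyond the scatter. Nothing given here accounts for this effect of the longer chain.

The compounds shown leave open whether a still longer chain, such as hexyl, would lower the number further or whether the trend stops at propyl. They also leave open how a chain ending in an amine, a hydroxyl or a phenyl ring would fare at this position.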